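A few compounds are considered here, and "the series" means these few. Any claim that something is new, unique, unknown or untested is made for them only; others in the source may bear on it.

All of these compounds share one core and differ only in the group on a carbonyl carbon. Compound 1 (`O=C(OC1CCC(CN2CCN(c3cc(=O)c4cc(C(F)(F)F)cc([N+](=O)[O-])c4s3)CC2)CC1)c1ccccc1`) carries a phenyl there, and compound 2 (`CC(=O)OC1CCC(CN2CCN(c3cc(=O)c4cc(C(F)(F)F)cc([N+](=O)[O-])c4s3)CC2)CC1`) carries a methyl. In an ADME assay on cells (Hepatocyte, Homo sapiens) for metabolic stability (a higher number here means that the compound lasts longer, a lower number that the compound disappears faster), compound 1 gives 0.603 h. Compound 2 gives < 0.15 h, which is a limit of the assay and not a number. That places compound 2 at the limit of < 0.15 h in this assay, at which 1 of the 2 values shown sits.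

Compound 3 (`O=C(OC1CCC(CN2CCN(c3cc(=O)c4cc(C(F)(F)F)cc([N+](=O)[O-])c4s3)CC2)CC1)c1ccc(C(F)(F)F)cc1`) has 4-(trifluoromethyl)phenyl in place of the methyl of compound 2 on that carbonyl carbon: 4-(trifluoromethyl)phenyl in place of methyl on a carbonyl carbon. Among the compounds with values here, the one measured step that bears on this change is methyl in place of phenyl at the same spot, which gave an at least 4.0-fold lower number from compound 1 to compound 2 (0.60 log units; beyond the scatter). Read in reverse, that step points to a longer half-life when an aromatic ring sits on the carbonyl carbon. Within the data shown here, it is a single pair, however, and no measured step shows what the trifluoromethyl on the ring adds. The expected change is an at least 4.0-fold higher number from compound 2 to compound 3 (0.60 log units; beyond the scatter), upward and beyond the scatter. For compound 3 the estimated half-life is 0.6 h, with an expected range from 0.25 h to 1.5 h.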

Compound 3, half-life: 0.117 h
Compound 3: middle estimate off by 5.1-fold (0.71 log units), on the high side; measured number below the stated range.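

In this assay, trifluoromethyl in place of hydrogen on an aromatic carbon gives a 5.2-fold lower number from compound 1 to compound 3 (0.71 log units; beyond the scatter). An aromatic ring on the carbonyl carbon therefore does not by itself bring a longer half-life: the link suggested by the phenyl of compound 1 and the methyl of compound 2 does not hold for compound 3, which goes against it, and what sits on the ring clearly matters at this position. The step from compound 2 to compound 3 cannot be read, because compound 2 stands at a limit of the assay and not at a number: the limit of < 0.15 h in this assay, at which 1 of the 3 values shown sits.

The compounds shown leave open whether this drop belongs to trifluoromethyl alone or would also appear with another group on the ring, such as a chlorine or a methoxy. They also leave open how a saturated ring such as cyclohexyl, or a longer chain such as ethyl, would behave on the carbonyl carbon, where a measured number would help to set the methyl of compound 2 against the aromatic rings.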